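Sulfonamide series: carbamoyl replacing 2-methylphenyl on the pyridine

The compounds below may be only part of what the source reports. "The series", "measured", "known", "first", "only" and "open" are said of these compounds alone.

Measured compounds:
- compound 1 `COc1ccc(C(N)=O)cc1S(=O)(=O)Nc1cccnc1`, in an assay on isolated protein for inhibition of alkaline phosphatase, tissue-nonspecific isozyme (Homo sapiens) (on this read-out higher numbers stand for weaker inhibition and lower numbers for stronger inhibition), compound 1 gives "not determined" (no result reported)
- compound 2 `COc1ccc(Cl)cc1S(=O)(=O)Nc1cncc(-c2ccccc2C)c1`, in this assay compound 2 gives "not determined" (no result reported)
- compound 3 `COc1ccc(Br)cc1S(=O)(=O)Nc1cccnc1`, in this assay compound 3 gives 543 nM

Going by the values given here, compound 2 stands without a number in this assay; compound 1 likewise has no number, so the only figure so far comes from compound 3. Among the compounds with values here, no step between two measured compounds can be worked out, and nothing here connects compound 2 to compound 3 by a single change.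

Compound 4 `COc1ccc(Cl)cc1S(=O)(=O)Nc1cncc(C(N)=O)c1` differs from compound 2 in one place: carbamoyl in place of 2-methylphenyl on an aromatic carbon. With compound 2 unmeasured, the size and direction of the step in this assay cannot be anchored; the expectation rests on compound 3 alone, whose value 543 nM is the only reference. On that basis compound 4 is expected to land near 1000 nM in this assay, with an estimated range from 200 nM to 5000 nM, and the measurement for compound 4 is still to come.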

Compound 4, half-maximal inhibitory concentration: 105 nM
Compound 4: middle estimate off by 9.5-fold (0.98 log units), on the high side, outside the stated range (below it).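

Going by these compounds alone, compound 2 has no single number in this assay, so no step to compound 4, at 105 nM, can be read. The compounds shown leave open the size and direction of the change from 2-methylphenyl to carbamoyl. No evidence shown bears on this result.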